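The source may report more compounds than this note shows. Statements on the series, on what has been measured and on what is new or still open speak of the compounds shown alone.

Three compounds have been measured so far in a functional assay on HCT-116 cells (Homo sapiens) for cytotoxicity, read by MTT assay, with a stated time of 48 h; a lower number here means a stronger inhibitor of growth, a higher number a weaker inhibitor of growth:

compound 1 `OC[C@H]1O[C@@H](n2cnc3cc(F)c(F)cc32)[C@H](O)[C@@H]1O` gives 67000 nM
compound 2 `O=[N+]([O-])c1ccccc1Cn1c(C(F)(F)F)nc2cc(Cl)c(Cl)cc21` gives 5900 nM
compound 3 `Clc1cc2ncn(C3CCCC3)c2cc1Cl` gives 37000 nM

Compound 3 stands within the scatter of compound 1 and beyond the scatter from compound 2, which has the lower number. Compound 4 `C[S+]([O-])c1nc2cc(Cl)c(Cl)cc2n1C1CCCC1` differs from compound 3 by a group of 3 heavy atoms (1 carbon, 1 oxygen, 1 sulfur; no ring) in place of a hydrogen atom, on an aromatic carbon on an aromatic carbon between two ring nitrogen atoms, next to the ring atom that bears the cyclopentyl group. Among the compounds with values here, no measured pair isolates a change at this place, so the expectation rests only on the spread of the three values, which reaches down to compound 2 at 5900 nM and no further. A modest move towards a lower number is expected, and the estimated 1.7-fold lower number from compound 3 to compound 4 (0.23 log units; within the scatter) is not clearly beyond the scatter. The estimated value for compound 4 is 22000 nM, with an expected range from 7000 nM to 60000 nM.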

Compound 4, concentration for 50% growth inhibition: 500 nM
Compound 4: the middle estimate sits 44-fold (1.64 log units) above what was measured; measured number below the stated range.
By their numbers in this assay, from the lowest: compound 4; then compound 2; then compounds 3 and 1 (each within the scatter of the next).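

In this assay, the aromatic carbon between two ring nitrogen atoms responds strongly to substitution: putting the group of 3 heavy atoms (1 carbon, 1 oxygen, 1 sulfur) in place of its hydrogen atom gives a 74-fold lower number from compound 3 to compound 4 (1.87 log units; beyond the scatter). Within the data shown here, this is the first pair that isolates a change at this place, and the step lies beyond the scatter. Nothing given here accounts for the size of this step.

From the compounds shown here alone, whether a methyl group, an amine or a carboxylic acid on this carbon would give a step of similar size remains open. So does whether the step would hold with another group in place of the cyclopentyl group.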